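The source may hold more compounds than are shown below. What is called first, only, known or untested is meant among the compounds shown, and "the series" means these compounds.

Working notes on the series. Compound 1 `COc1ccc(-c2cc(/C=C/C(=O)c3ccc(N)cc3)[nH]n2)cc1` and compound 3 `COc1ccc(-c2cc(/C=C/C(=O)c3ccc(N)cc3)[nH]n2)cc1OC` share a core; the change between them is methoxy in place of hydrogen on an aromatic carbon. In a functional assay on OVCAR-5 cells (Homo sapiens) for cytotoxicity, read by sulforhodamine B assay, with a stated time of 48 h, tested at 0.1 uM (a higher number here means a weaker effect of the compound at the concentration tested, a lower number a stronger effect), compound 1 gives 95%, and compound 3 gives 95%; the step of no change at the digits printed from compound 1 to compound 3 (within the scatter). Compound 2 `COc1ccc(C(=O)/C=C/c2cc(-c3cc(OC)c(OC)c(OC)c3)n[nH]2)cc1OC` is built on a different core, and the difference between the two cores is not broken down here. In this assay compound 2 gives 88%, which lies within the scatter of the values of compound 1 and compound 3. Compound 4 `COc1cc(C(=O)/C=C/c2cc(-c3cc(OC)c(OC)c(OC)c3)n[nH]2)cc(OC)c1OC` is not yet measured. It carries the same kind of change as compound 3, namely (methoxy in place of hydrogen on an aromatic carbon), with the surroundings differing in that the entering group is also meta to a methoxy group. For compound 4 the step of no change at the digits printed from compound 2 to compound 4 (within the scatter) is expected, because the comparable step no change at the digits printed from compound 1 to compound 3 (within the scatter). Compound 4 is therefore estimated at 88%, between 75% and 99%.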

Compound 4, a percentage reported as activity, at one concentration (the size of the read-out at that concentration, not a potency): 101%
Estimate against measurement, compound 4: 13 percentage points below, and the stated range ends below it.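

In this assay, methoxy in place of hydrogen on an aromatic carbon gives a number 13 percentage points higher from compound 2 to compound 4 (beyond the scatter), while the same change on the other core gives no change at the digits printed from compound 1 to compound 3 (within the scatter). The two steps cannot be told apart, so these data do not show that the outcome of the change depends on the core: the same change on two cores in this assay, no change at the digits printed (within the scatter) from compound 1 to compound 3 and a number 13 percentage points higher (beyond the scatter) from compound 2 to compound 4, 13 percentage points apart, within the scatter of two such steps

Nor do two steps at a single concentration show that the change behaves alike on both cores or would carry over to any further core in the series. Still open, from the compounds shown here alone, is how a hydroxyl, an ethoxy chain or a carboxylic acid would read out in place of this methoxy. Also open, going by these compounds, is whether either step would hold at another concentration.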